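A few compounds are considered here, and "the series" means these few. Any claim that something is new, unique, unknown or untested is made for them only; others in the source may bear on it.

In a functional assay on HL-60 cells (Homo sapiens) for cytotoxicity, read by ELISA, with a stated time of 2 days (a lower number here means a stronger inhibitor, a higher number a weaker inhibitor), compound 1 `Oc1cccc(-c2cc(-c3ccccc3)cc(-c3cccs3)n2)c1` gives 14100 nM as the middle of three values, within the scatter of compound 2 `Oc1cccc(-c2cc(-c3ccccc3)cc(-c3ccco3)n2)c1` at 9910 nM and of compound 3 `Oc1cccc(-c2cc(-c3ccccc3)cc(-c3ccncc3)n2)c1` at 23900 nM on the same scale. Compound 4 `Oc1ccc(-c2cc(-c3ccccc3)cc(-c3cccs3)n2)cc1` differs from compound 1 by 4-hydroxyphenyl in place of 3-hydroxyphenyl on an aromatic carbon in a single swap: 4-hydroxyphenyl in place of 3-hydroxyphenyl on an aromatic carbon, next to the ring nitrogen. Within the data shown here, no measured step moves that hydroxyl. The nearest evidence comes from swapping the thiophen-2-yl, furan-2-yl and pyridin-4-yl groups: a 1.4-fold lower number from compound 1 to compound 2 (0.15 log units; within the scatter) and a 1.7-fold higher number from compound 1 to compound 3 (0.23 log units; within the scatter) stay within the scatter, and a 2.4-fold higher number from compound 2 to compound 3 (0.38 log units; beyond the scatter) is modest. The estimated change is a 1.1-fold lower number from compound 1 to compound 4 (0.04 log units; within the scatter) with no direction favoured and none beyond the scatter expected. For compound 4 the expected value is 13000 nM with an estimated range from 5500 nM to 30000 nM in this series.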

Compound 4, half-maximal inhibitory concentration: 1700 nM
The estimate for compound 4 lay 7.6-fold (0.88 log units) above the measured number; measured number outside the range, below it.
By their numbers in this assay, from the lowest: compound 4; then compounds 2, 1 and 3 (each within the scatter of the next, the first and the last beyond it).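

In this assay, this position responds to where the hydroxyl sits on the phenyl group: 4-hydroxyphenyl in place of 3-hydroxyphenyl gives an 8.3-fold lower number from compound 1 to compound 4 (0.92 log units; beyond the scatter). The swap leaves the atoms and the counted donors and acceptors unchanged, so the arrangement alone separates the pair. Nothing available explains the step.

Open, on these data alone, is whether 4-hydroxyphenyl gives a similar step alongside furan-2-yl or pyridin-4-yl in place of thiophen-2-yl. Also open, as far as these compounds go, is whether the hydroxyl itself matters, which 4-methoxyphenyl or 4-aminophenyl at this position would test.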